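Amide swap on the shared core: imidazolyl to 2-methylphenyl

The compounds below may be only part of what the source reports. "The series", "measured", "known", "first", "only" and "open" are said of these compounds alone.

Measured so far in a toxicity assay on THP-1 cells (Homo sapiens) for inhibition; on this read-out lower numbers stand for higher toxicity in this test and higher numbers for lower toxicity in this test:
compound 1 `COc1ccc(-c2cnc(NC(=O)c3ncc[nH]3)n2C)cc1`: > 100000 nM
compound 2 `Cn1c(-c2ccc(Br)cc2)cnc1NC(=O)c1ccc(F)cc1`: 46000 nM
compound 3 `CCCn1c(-c2ccc(OC)cc2)cnc1NC(=O)c1ccc(F)cc1`: > 100000 nM

Compound 1 carries the imidazole amide on the shared core. In this assay compound 1 reaches only a limit of the assay, > 100000 nM. For compound 3, with the propyl on the core nitrogen, the result in this assay is likewise only a limit, > 100000 nM. Among the compounds with values here, compound 2, with the bromo phenyl, is the one member with a number in this assay, 46000 nM. The picture so far is one of little toxicity, set by the limit of > 100000 nM in this assay, at which 2 of the 3 values shown sit.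

Compound 4 `COc1ccc(-c2cnc(NC(=O)c3ccccc3C)n2C)cc1` is the next step from compound 1: 2-methylphenyl in place of 1H-imidazol-2-yl on a carbonyl carbon. Within the data shown here, no step between measured compounds separates these two groups, so the effect of the change can only be estimated. Given that compound 2 gives 46000 nM in this assay with a carbon-only aromatic amide, a small step towards higher toxicity is expected in this assay for compound 4, roughly an at least 1.3-fold lower number from compound 1 to compound 4 (0.12 log units; that floor lies within the scatter), but likely within or close to the scatter. The estimate for compound 4 in this assay is 75000 nM, expected between 30000 nM and 200000 nM, with a fair chance of another limit.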

Compound 4, half-maximal cytotoxic concentration: > 100000 nM
Compound 4 ended at the assay's limit; the forecaster's own chance of this, stated with the estimate: 45%; at least 1.3-fold (0.12 log units) between middle value and limit.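

In this assay compound 1 and compound 4 both end at a limit of the assay, so the step between them cannot be read. Still open, on these data alone, is whether 2-methylphenyl in place of 1H-imidazol-2-yl on a carbonyl carbon changes this read-out at all.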